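Compound 3 to compound 4: changing the aryl group on the carbonyl

The compounds below may be only part of what the source reports. "The series", "measured", "known", "first", "only" and "open" are said of these compounds alone.

In an in vitro ADME assay on microsomes from liver (Homo sapiens) for metabolic stability (on this read-out higher numbers stand for fast clearance and lower numbers for slow clearance), compound 3 (`O=C(C=C1CCN(C(=O)c2cccc(F)c2)CC1)N[C@@H]1CCN(Cc2ccc3cc(F)ccc3c2)C1`) gives 459 mL/min/kg as its clearance. Compound 1 (`COc1cccc(O)c1C(=O)N1CCC(=CC(=O)N[C@@H]2CCN(Cc3ccc4cc(F)ccc4c3)C2)CC1`) gives 192 mL/min/kg and compound 2 (`COc1ccc(C(=O)N2CCC(=CC(=O)N[C@@H]3CCN(Cc4ccc5cc(F)ccc5c4)C3)CC2)c(O)c1`) gives 232 mL/min/kg on the same read-out. Compound 3 stands clear of compound 1 only: a 2.4-fold higher number from compound 1 to compound 3 (0.38 log units; beyond the scatter) is beyond the scatter, while a 2.0-fold higher number from compound 2 to compound 3 (0.30 log units; within the scatter) and a 1.2-fold higher number from compound 1 to compound 2 (0.08 log units; within the scatter) are within it. Compound 4 (`O=C(C=C1CCN(C(=O)c2ccc(Cl)cc2O)CC1)N[C@@H]1CCN(Cc2ccc3cc(F)ccc3c2)C1`) brings 4-chloro-2-hydroxyphenyl in place of 3-fluorophenyl on a carbonyl carbon with 4-chloro-2-hydroxyphenyl in place of 3-fluorophenyl on a carbonyl carbon. Among the compounds with values here, compound 1 and compound 2 also carry a hydroxy group on that ring, but no measured compound carries chlorine. A lower number is expected, the estimated step being a 1.8-fold lower number from compound 3 to compound 4 (0.26 log units; within the scatter) in this assay for this change. The estimate for compound 4 is 250 mL/min/kg with an expected range of 130 mL/min/kg to 450 mL/min/kg in this series.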

Compound 4, clearance: 87 mL/min/kg
The estimate for compound 4 lay 2.9-fold (0.46 log units) above the measured number; the measured number lies below the stated range.
By their numbers in this assay, from the lowest: compound 4; then compounds 1, 2 and 3 (each within the scatter of the next, the first and the last beyond it).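

In this assay, within the data shown here, the aryl group on the carbonyl moves the clearance further than the earlier compounds showed: 4-chloro-2-hydroxyphenyl in place of 3-fluorophenyl gives a lower number (a 5.3-fold lower number from compound 3 to compound 4 (0.72 log units; beyond the scatter)). With the hydroxy group kept, chloro in place of methoxy also lowers it (a 2.7-fold lower number from compound 2 to compound 4 (0.43 log units; beyond the scatter)), as does the change from 2-hydroxy-6-methoxyphenyl (a 2.2-fold lower number from compound 1 to compound 4 (0.34 log units; beyond the scatter)). Nothing at hand explains these steps.

Still open, as far as these compounds go, is how a phenyl ring carrying chloro without the hydroxy group would read. From the compounds shown here alone, a nitrile or a carboxylic acid in place of chloro is equally open.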